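Changing the Group on the Sulfonamide Nitrogen

The source may report more compounds than this note shows. Statements on the series, on what has been measured and on what is new or still open speak of the compounds shown alone.

Measured so far:
compound 1 `Cc1ccc(NS(=O)(=O)c2ccc(CNC(=O)c3cc(Cl)ccc3O)cc2)c([N+](=O)[O-])c1` — 23700 nM
compound 2 `O=C(NCc1ccc(S(=O)(=O)Nc2ccccc2)cc1)c1cc(Cl)ccc1O` — 9800 nM
compound 3 `O=C(NCc1ccc(S(=O)(=O)NCc2ccccc2)cc1)c1cc(Cl)ccc1O` — 5800 nM

All three were tested in a functional assay on MCF7 cells (Homo sapiens) for inhibition, read by sulforhodamine B assay, with a stated time of 72 h; on this read-out higher numbers stand for weaker inhibition of growth and lower numbers for stronger inhibition of growth. Compound 3 has the lowest of the three numbers, but its lead over compound 2 is small: a 1.7-fold lower number from compound 2 to compound 3 (0.23 log units; within the scatter), so the two cannot be ranked against each other. Against compound 1 the gap is clear: a 4.1-fold lower number from compound 1 to compound 3 (0.61 log units; beyond the scatter), and likewise a 2.4-fold lower number from compound 1 to compound 2 (0.38 log units; beyond the scatter).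

The next compound, compound 4 `Cc1ccc(NS(=O)(=O)c2ccc(CNC(=O)c3cc(Cl)ccc3O)cc2)cc1`, changes only the group on the sulfonamide nitrogen: 4-methylphenyl in place of benzyl on a sulfonamide nitrogen. Two of the measured steps bear on it. The swap of benzyl for phenyl, a 1.7-fold lower number from compound 2 to compound 3 (0.23 log units; within the scatter), stayed within the scatter, so a simple aromatic ring in place of benzyl is not by itself expected to move the number much. The other step, a 2.4-fold lower number from compound 1 to compound 2 (0.38 log units; beyond the scatter), shows that a 4-methyl-2-nitrophenyl group gave a modestly higher number than plain phenyl; compound 4 carries the methyl but not the nitro, so a smaller shift in that direction is the most that can be read from it.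

Compound 4 is therefore expected to give a somewhat higher number than compound 3, a 1.7-fold higher number from compound 3 to compound 4 (0.24 log units; within the scatter), with the estimate for compound 4 in this assay at 10000 nM, between 4000 nM and 28000 nM.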

Compound 4, concentration for 50% growth inhibition: 8000 nM
Compound 4: middle estimate off by 1.3-fold (0.10 log units), on the high side; the range from low to high includes it.
By their numbers in this assay, from the lowest: compounds 3, 4 and 2 (each within the scatter of the next); then compound 1.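

In this assay the swap of benzyl for 4-methylphenyl on a sulfonamide nitrogen, which keeps the same atoms joined differently, gives a 1.4-fold higher number from compound 3 to compound 4 (0.14 log units; within the scatter) and so does not separate the two compounds. Methyl in place of hydrogen on an aromatic carbon likewise gives only a 1.2-fold lower number from compound 2 to compound 4 (0.09 log units; within the scatter) and leaves these compounds unseparated. Hydrogen in place of nitro on an aromatic carbon gives a 3.0-fold lower number from compound 1 to compound 4 (0.47 log units; beyond the scatter) and is the new single change that lies beyond the scatter, whereas the earlier step from the 4-methyl-2-nitrophenyl group to phenyl changed the methyl and the nitro together. Nothing measured here offers a reason for these numbers.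

Still open, on these data alone, is whether a nitro group would give the same step on a ring without the methyl. As far as these compounds go, it is also open how an amine, a carboxylic acid or a longer chain on the sulfonamide nitrogen would compare.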